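Replacing 3-(trifluoromethyl)phenyl with 4-(methoxycarbonyl)phenyl

The source may report more compounds than this note shows. Statements on the series, on what has been measured and on what is new or still open speak of the compounds shown alone.

In a functional assay (aorta) with Rattus norvegicus as the target (a higher number here means a weaker inhibitor, a lower number a stronger inhibitor), compound 1 `CC1(C)Oc2ccc(C#N)cc2[C@@H](/N=C(\NC#N)Nc2ccccc2)[C@@H]1O` gives 1400 nM; 1300 nM (2 entries), and its repeat entries agree closely (the several entries of compound 1 in this assay, 1400 nM; 1300 nM (2 entries)). Compound 2 `CC1(C)Oc2ccc(C#N)cc2[C@@H](/N=C(\NC#N)NCc2ccccc2)[C@@H]1O` gives 2400 nM, and compound 3 `CC1(C)Oc2ccc(C#N)cc2[C@@H](/N=C(\NC#N)Nc2cccc(C(F)(F)F)c2)[C@@H]1O` gives 1600 nM. Compound 3 thus stands level with the other two, as the measured step of a 1.5-fold lower number from compound 2 to compound 3 (0.18 log units; within the scatter) lies within the scatter. Compound 4 `COC(=O)c1ccc(N/C(=N/[C@@H]2c3cc(C#N)ccc3OC(C)(C)[C@H]2O)NC#N)cc1` carries 4-(methoxycarbonyl)phenyl in place of 3-(trifluoromethyl)phenyl on an amine nitrogen. Among the compounds with values here, only that one step bears on this change, as it alters the group on the same nitrogen, and no measured compound carries the new group. No step beyond the scatter is therefore expected in this assay, and the estimated step is a 1.1-fold lower number from compound 3 to compound 4 (0.03 log units; within the scatter). For compound 4 the expected value is 1500 nM, within an estimated range of 600 nM to 3800 nM.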

Compound 4, half-maximal inhibitory concentration: 18400 nM
Compound 4: middle estimate off by 12-fold (1.09 log units), on the low side; the measured number lies above the stated range.
By their numbers in this assay, from the lowest: compounds 3 and 2 (each within the scatter of the next); then compound 4.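

In this assay, the amine nitrogen proves sensitive to the group it carries: the earlier step there stayed within the scatter, whereas 4-(methoxycarbonyl)phenyl brings a 12-fold higher number from compound 3 to compound 4 (1.06 log units; beyond the scatter) and a 7.7-fold higher number from compound 2 to compound 4 (0.88 log units; beyond the scatter). Both steps lie beyond the scatter, and repeat measurements agree closely: the several entries of compound 1 in this assay, 1400 nM; 1300 nM (2 entries).

The compounds shown cannot separate the methoxycarbonyl group itself from its place on the ring, since group and place change together. From the compounds shown here alone, whether a carboxylic acid or a primary amide at that place would give a similarly high number also stays open.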